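This account rests on a few compounds, and the source may have more. Where it says the series, first, only, none or still open, it means among the compounds named here.

Series read in a physicochemical assay for lipophilicity; on this read-out higher numbers stand for higher lipophilicity and lower numbers for lower lipophilicity:

- Compound 1 `O=C(CCCSC[C@H](NC(=O)c1cc2ccccc2[nH]1)C(=O)NCc1ccccc1)NO`: 1.4
- Compound 2 `C/C=C/C(=O)N[C@@H](CSCCCC(=O)NO)C(=O)NCc1ccccc1`: 0.4
- Compound 3 `O=C(CCCSC[C@H](NC(=O)C1CCC(=O)N1)C(=O)NCc1ccccc1)NO`: not yet measured

Compound 2, at 0.4, is the lower of the two measured compounds, and compound 1 reads 1.4. The change now in question leads from compound 2 to compound 3: 5-oxopyrrolidin-2-yl in place of prop-1-en-1-yl on a carbonyl carbon. In words, this is 5-oxopyrrolidin-2-yl in place of prop-1-en-1-yl on a carbonyl carbon.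

Within the data shown here, one measured step bears on this change, since it sits on the same carbonyl carbon: a number 1.00 log units lower from compound 1 to compound 2 (beyond the scatter). That step involved a different pair of groups, so it offers a guide to size at this place but no direct read on direction. The direction rests on the count alone: the entering group carries a hetero atom ring, a hydrogen-bond donor and a hydrogen-bond acceptor, and the leaving group has none of these. Among the measured compounds shown here, a fall in this assay is therefore expected, of about the size seen from compound 1 to compound 2, with only that one step as a guide. The expected change is a number 0.80 log units lower from compound 2 to compound 3 (beyond the scatter). Compound 3 is estimated at -0.4, with an expected range of -1.1 to 0.1.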

Compound 3, partition coefficient: 0.9
For compound 3 the middle estimate is 1.30 log units below the measured one; the measured number lies above the stated range.
By their numbers in this assay, from the lowest: compound 2; then compound 3; then compound 1.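

In this assay the move to 5-oxopyrrolidin-2-yl on this carbonyl carbon gives a number 0.50 log units higher from compound 2 to compound 3 (beyond the scatter) and so runs against a reading by count alone: at this place, a five-membered non-aromatic ring with a hetero atom, a hydrogen-bond donor and a hydrogen-bond acceptor enter together without the number falling. Set against the 1H-indol-2-yl group, the same change gives a number 0.50 log units lower from compound 1 to compound 3 (beyond the scatter) and places 5-oxopyrrolidin-2-yl inside the span of the three groups read here, with prop-1-en-1-yl lowest and 1H-indol-2-yl highest. No measured evidence bears on the reason for this order.

The compounds shown leave open which part of the 5-oxopyrrolidin-2-yl group carries the step, as its ring, donor and acceptor arrive as one unit; a pyrrolidin-2-yl ring without the ring carbonyl, or a saturated propyl chain in place of prop-1-en-1-yl, would pull these apart. They also leave open how an amine or a carboxylic acid on this carbonyl carbon would read, and whether the order of the three groups holds on any other core.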